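The source may hold more compounds than are shown below. What is called first, only, known or untested is meant among the compounds shown, and "the series" means these compounds.

Working notes on the series, all read in a functional assay on HepG2 cells (Homo sapiens) for antiproliferative activity, read by MTT assay, with a stated time of 48 h; a lower number here means that less compound is needed, a higher number that more compound is needed for the effect. Compound 1 (`CC1=NN(C(=O)CCl)C(c2cc(Cl)ccc2O)C1`) gives 20300 nM, and compound 2 (`COc1ccc(C(=O)N2N=C(C)CC2c2ccccc2O)cc1`) gives 40300 nM. Compound 3 (`CC1=NN(S(=O)(=O)c2ccccc2C)C(c2cc(Br)ccc2O)C1`) gives 39300 nM, which lies within the scatter of both compound 2 and compound 1. Compound 4 (`CC1=NN(S(=O)(=O)c2ccccc2I)C(c2cc(Br)ccc2O)C1`) has not yet been measured. It carries iodo in place of methyl on an aromatic carbon, ortho to a large group, so 2-methylphenyl becomes 2-iodophenyl: iodo in place of methyl on an aromatic carbon. Among the compounds with values here, no measured pair differs in one place, so this swap has no direct precedent. The expected step, a 1.2-fold lower number from compound 3 to compound 4 (0.09 log units; within the scatter), is none beyond the scatter in this assay. For compound 4 the estimated value is 32000 nM, with an expected range of 15000 nM to 70000 nM.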

Compound 4, half-maximal effective concentration: > 60000 nM
Compound 4 gave a limit, no number; the forecaster's own chance of this, stated with the estimate: 10%; at least 1.8-fold (0.27 log units) between middle value and limit.
By their numbers in this assay, from the lowest: compounds 1, 3 and 2 (each within the scatter of the next). At a limit, above all of these: compound 4.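

In this assay compound 4 reads only as a limit, not a number: the limit of > 60000 nM in this assay, at which 1 of the 4 values shown sits. Iodo in place of methyl on an aromatic carbon, ortho to a large group, gives an at least 1.5-fold higher number from compound 3 to compound 4 (0.18 log units; that floor lies within the scatter), the first step readable at this position. From the compounds shown here alone, the swap therefore brings no lower number here, although the true size of the step remains unknown.

The limit leaves open whether the step truly lies beyond the scatter. The compounds shown also leave open how an amine or a carboxylic acid would read in place of methyl at this position.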